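Replacing the 3-fluorophenyl group of compound 1

The source may hold more compounds than are shown below. What is called first, only, known or untested is meant among the compounds shown, and "the series" means these compounds.

Measured in a functional assay on a cell-free system (Platelet, plasma, Homo sapiens) for inhibition; a higher number here means a weaker inhibitor, a lower number a stronger inhibitor:
Compound 1 `Cc1ccc(N(CCN2CCC(OCC(=O)O)CC2)C(=O)c2cccc(F)c2)cc1`: 160 nM
Compound 2 `O=C(O)COC1CCN(CCN(C(=O)c2ccc(Cl)cc2)c2ccc(Cl)cc2)CC1`: 1500 nM
Compound 3 `O=C(O)COC1CCN(CCN(C(=O)c2cccc(F)c2)c2ccc(Cl)cc2)CC1`: 340 nM

Compound 1 has the lowest number of the three and is the strongest inhibitor so far. Compound 4 `COc1ccc(C(=O)N(CCN2CCC(OCC(=O)O)CC2)c2ccc(C)cc2)cc1OC` differs from it in one place: 3,4-dimethoxyphenyl in place of 3-fluorophenyl on a carbonyl carbon. There, 3,4-dimethoxyphenyl stands in place of 3-fluorophenyl on a carbonyl carbon. One measured step changes the group at this place: a 4.4-fold lower number from compound 2 to compound 3 (0.64 log units; beyond the scatter), a modest step with 3-fluorophenyl in place of 4-chlorophenyl. The other, a 2.1-fold higher number from compound 1 to compound 3 (0.33 log units; beyond the scatter), is chloro in place of methyl on an aromatic carbon, which compound 4 does not share. Going by the values given here, no measured compound carries 3,4-dimethoxyphenyl, so the direction remains uncertain. In this assay, a modest rise is expected: a 2.2-fold higher number from compound 1 to compound 4 (0.34 log units; beyond the scatter). For compound 4, the estimated value is 350 nM, with an expected range of 100 nM to 1300 nM.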

Compound 4, half-maximal inhibitory concentration: > 3000 nM
Compound 4 ended at the assay's limit (the forecaster's own chance of this, stated with the estimate: 3%); middle value at least 8.5-fold (0.93 log units) away from the limit.
By their numbers in this assay, from the lowest: compound 1; then compound 3; then compound 2. At a limit, above all of these: compound 4.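

In this assay, going by these compounds alone, the group on the carbonyl carbon proves able to cost far more than the earlier compounds showed: 3,4-dimethoxyphenyl in place of 3-fluorophenyl gives an at least 18-fold higher number from compound 1 to compound 4 (1.27 log units; beyond the scatter). Within the data shown here, that step exceeds the only earlier change at this place, a 4.4-fold lower number from compound 2 to compound 3 (0.64 log units; beyond the scatter). The value of compound 4 is a limit and not a number: the limit of > 3000 nM in this assay, at which 1 of the 4 values shown sits.

The compounds shown leave open whether a phenyl with a single methoxy group, a hydroxyl group or an amine on this carbonyl carbon would keep the inhibition of compound 1. They also leave open which of the two methoxy groups accounts for the step.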